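Replacing pent-1-en-1-yl with 2-methylprop-1-en-1-yl on the carbonyl carbon

A few compounds are considered here, and "the series" means these few. Any claim that something is new, unique, unknown or untested is made for them only; others in the source may bear on it.

Measured in a functional assay on A549 cells (Homo sapiens) for antiproliferative activity, read by MTT assay, with a stated time of 72 h (a higher number here means a weaker inhibitor, a lower number a stronger inhibitor), so far:
- Compound 1 (`C/C=C/C(=O)Nc1cccc(Oc2nc(Nc3ccn(C)n3)nc3c2CSCC3)c1`) gives > 50000 nM as a limit of the assay
- Compound 2 (`CCC/C=C/C(=O)Nc1cccc(Oc2nc(Nc3ccn(C)n3)nc3c2CSCC3)c1`) gives 8190 nM as a true number

Among the measured compounds shown here, compound 2, at 8190 nM in this assay, holds the only true number so far. Compound 1 has only a limit to show (the limit of > 50000 nM in this assay, at which 1 of the 2 values shown sits).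

The next compound, compound 3 (`CC(C)=CC(=O)Nc1cccc(Oc2nc(Nc3ccn(C)n3)nc3c2CSCC3)c1`), keeps the shared core and differs from compound 2 in one place, with 2-methylprop-1-en-1-yl in place of pent-1-en-1-yl on a carbonyl carbon.

For the measured compounds named here, one measured step bears on this change. On the strength of an at least 6.1-fold lower number from compound 1 to compound 2 (0.78 log units; beyond the scatter), with ethyl in place of hydrogen on a saturated chain carbon bound to a double-bonded chain carbon, compound 3 is expected to give back part of that gain in this assay and to show a higher number. The expected change is a 2.7-fold higher number from compound 2 to compound 3 (0.43 log units; beyond the scatter), and a reading that reaches only a limit would not be surprising. For compound 3 the estimated value is 22000 nM (range 8000 nM to 60000 nM).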

Compound 3, half-maximal inhibitory concentration: 44200 nM
The estimate for compound 3 lay 2.0-fold (0.30 log units) below the measured number; low and high end bracket the measured number.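

In this assay, the earlier pair showed only that lengthening the chain on the double bond lowers the number, whereas this result shows that the position also responds to a branched group: the change to 2-methylprop-1-en-1-yl is a modest step and gives a 5.4-fold higher number from compound 2 to compound 3 (0.73 log units; beyond the scatter). Pent-1-en-1-yl, with 5 heavy atoms, is so far the only group at this carbonyl carbon that gives a clear gain, and 2-methylprop-1-en-1-yl, with 4, does not keep it, although both groups retain the double bond and neither adds a ring, donor or acceptor. The change from prop-1-en-1-yl to 2-methylprop-1-en-1-yl gives an at least 1.1-fold lower number from compound 1 to compound 3 (0.05 log units; that floor lies within the scatter), so no order can be given for that pair. That step rests on a floor alone, because compound 1 has only a limit of the assay: the limit of > 50000 nM in this assay, at which 1 of the 3 values shown sits.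

The change from compound 2 to compound 3 alters chain length and branching together, so the compounds shown cannot separate the two, and an unbranched but-1-en-1-yl group would be needed to tell them apart. They also leave open whether a longer chain such as hex-1-en-1-yl would lower the number further, and whether the double bond matters at all, which a saturated pentyl chain would test.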